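Swapping Methoxyphenoxy for Benzyl: Expected Solubility

The source may hold more compounds than are shown below. What is called first, only, known or untested is meant among the compounds shown, and "the series" means these compounds.

Measured so far:
compound 1 `COc1ccccc1Oc1ccc2c(NCCCNCc3ccco3)ccnc2c1` — 14500 nM
compound 2 `COc1cccc(CNCCCNc2ccnc3cc(CC4CCCCC4)ccc23)c1O` — 4200 nM

In a physicochemical assay for solubility, with a stated time of 18 h, at pH 7.4 (on this read-out higher numbers stand for higher solubility and lower numbers for lower solubility), compound 1 gives 14500 nM, the higher of the two numbers shown. Compound 2 gives 4200 nM in this assay, a gap beyond the usual scatter. Compound 3 `c1ccc(Cc2ccc3c(NCCCNCc4ccco4)ccnc3c2)cc1` has not yet been measured. It differs from compound 1 in one place: benzyl in place of 2-methoxyphenoxy on an aromatic carbon. Within the data shown here, no measured pair shows this change, so no directly comparable step exists. Compound 3 is expected to come out lower than compound 1, a step of a 2.9-fold lower number from compound 1 to compound 3 (0.46 log units; beyond the scatter). Compound 3 is estimated at 5000 nM, within a range from 1500 nM to 15000 nM.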

Compound 3, solubility: 4200 nM
Estimate against measurement, compound 3: 1.2-fold (0.08 log units) above; measured number inside the range.
By their numbers in this assay, from the lowest: compounds 2 and 3 (each within the scatter of the next); then compound 1.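

In this assay benzyl in place of 2-methoxyphenoxy on an aromatic carbon of the shared core gives a 3.5-fold lower number from compound 1 to compound 3 (0.54 log units; beyond the scatter) and this step lies beyond the usual scatter. Among these compounds, it is the first direct comparison at this position, and it shows that the read-out can shift when only this group is exchanged. No measurement available here explains the step.

Still open, on these data alone, is where an amine, a carboxylic acid or a plain phenoxy at this position would fall on this read-out. Also open, as far as these compounds go, is whether the same swap gives a similar step when the side chain differs.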